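Cytotoxicity limits in the semicarbazone series: compound 2 to compound 4

The source may report more compounds than this note shows. Statements on the series, on what has been measured and on what is new or still open speak of the compounds shown alone.

Measured in an ADME assay on BHK-21 cells (Mesocricetus auratus) for cytotoxicity, read by MTT assay; a higher number here means that more compound is tolerated, a lower number that less compound is tolerated:
compound 1 `C/C(=N\NC(N)=O)c1ccc2[nH]c(-c3ccccc3)nc2c1` gives > 100000 nM (a limit)
compound 2 `C/C(=N\NC(N)=O)c1ccc2[nH]c(-c3ccc(Cl)cc3)nc2c1` gives > 100000 nM (a limit)
compound 3 `C/C(=N\NC(N)=O)c1ccc2c(c1)nc(-c1ccc(Cl)cc1)n2C1CCCCC1` gives > 100000 nM (a limit)

For compound 2, > 100000 nM is a limit and not a number, and its two neighbours offer no number either. The whole set is described by the limit of > 100000 nM in this assay, at which 3 of the 3 values shown sit, and nothing finer.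

Compound 4 `C/C(=N\NC(N)=O)c1ccc2[nH]c(C3CCCCC3)nc2c1` carries cyclohexyl in place of 4-chlorophenyl on an aromatic carbon of the shared core, the change from compound 2 (cyclohexyl in place of 4-chlorophenyl on an aromatic carbon).

Within the data shown here, two measured steps bear on this: a step that the two limits leave unreadable from compound 1 to compound 2 for chloro in place of hydrogen on an aromatic carbon, and a step that the two limits leave unreadable from compound 2 to compound 3 for cyclohexyl in place of hydrogen on an aromatic nitrogen. Neither has a readable size, so neither can be carried over as a number.

Compound 3 holds 4-chlorophenyl and cyclohexyl together and still gives only a limit (> 100000 nM). Neither measured step shows any loss of tolerance, so no step beyond the scatter is expected in this assay.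

The estimated change is a number no higher from compound 2 to compound 4 (the limit leaves the size open) and is expected to be small. The estimate for compound 4 is 100000 nM, with an expected range of 40000 nM to 250000 nM, and a report as a limit only is the likely outcome.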

Compound 4, half-maximal cytotoxic concentration: > 100000 nM
Compound 4 was reported as a limit (the forecaster's own chance of this, stated with the estimate: 85%); the middle value sits exactly at the limit.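

In this assay no new step can be read: compound 4, like compound 1 and compound 2, is reported only as a limit, so neither comparison has a size. The compounds shown leave open the concentration at which any of them stops being tolerated, and whether they differ at all, because a single limit describes the whole set: the limit of > 100000 nM in this assay, at which 4 of the 4 values shown sit.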